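The source may report more compounds than this note shows. Statements on the series, on what has been measured and on what is new or still open speak of the compounds shown alone.

Measured so far in a functional assay on HT-29 cells (Homo sapiens) for cytotoxicity, read by MTT assay, with a stated time of 72 h; on this read-out lower numbers stand for stronger inhibition and higher numbers for weaker inhibition:
Compound 1 `COc1cc2c(Oc3ccc(NC(=O)c4nn(-c5ccccc5)c(=O)c5ccccc45)cc3F)ccnc2cc1OCCCN1CCCC1` gives 980 nM.
Compound 2 `COc1cc2c(Oc3ccc(NC(=O)c4nn(-c5ccc([N+](=O)[O-])cc5)c(=O)c5ccccc45)cc3F)ccnc2cc1OCCCN1CCCC1` gives 1760 nM.

For the measured compounds named here, of these two numbers, the one for compound 2 is at the top, but the step of a 1.8-fold higher number from compound 1 to compound 2 (0.25 log units; within the scatter) lies within the scatter, so the two are not really told apart. Compound 3 `COc1ccc(-n2nc(C(=O)Nc3ccc(Oc4ccnc5cc(OCCCN6CCCC6)c(OC)cc45)c(F)c3)c3ccccc3c2=O)cc1` is not yet measured. It differs from compound 2 by methoxy in place of nitro on an aromatic carbon, para to a large group. Going by the values given here, the only measured step at this position, a 1.8-fold higher number from compound 1 to compound 2 (0.25 log units; within the scatter), stayed within the scatter, so no step beyond the scatter is expected in this assay. Compound 3 is estimated at 1200 nM, between 500 nM and 3000 nM. The expected step is a 1.5-fold lower number from compound 2 to compound 3 (0.17 log units; within the scatter).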

Compound 3, half-maximal inhibitory concentration: 2360 nM
Estimate against measurement, compound 3: 2.0-fold (0.29 log units) below; low and high end bracket the measured number.
By their numbers in this assay, from the lowest: compounds 1, 2 and 3 (each within the scatter of the next, the first and the last beyond it).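

In this assay, the 4-nitrophenyl and 4-methoxyphenyl compounds cannot be told apart, with a 1.3-fold higher number from compound 2 to compound 3 (0.13 log units; within the scatter). Methoxy in place of hydrogen, however, gives a 2.4-fold higher number from compound 1 to compound 3 (0.38 log units; beyond the scatter), the first step at this position to pass the scatter, though only a modest one. Nothing measured here explains this result. On these data alone, whether an amine or a carboxylic acid at this spot would give a similar number remains open. So does the effect of a chain longer than methoxy.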